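Urea aryl swap on the pyrazole series: compound 4

This account rests on a few compounds, and the source may have more. Where it says the series, first, only, none or still open, it means among the compounds named here.

Of the compounds shown here, three have been measured in a functional assay on UACC-257 cells (Homo sapiens) for inhibition, read by sulforhodamine B assay, with a stated time of 48 h; on this read-out higher numbers stand for weaker inhibition of growth and lower numbers for stronger inhibition of growth. Compound 1 `COc1cc(-c2nn(-c3cccc(NC(=O)Nc4cccc(C(F)(F)F)c4)c3)cc2-c2ccncc2)ccc1Cl` gives 923 nM. Compound 2 `O=C(Nc1cccc(-n2cc(-c3ccncc3)c(-c3ccc(Cl)c(O)c3)n2)c1)Nc1cccc(C(F)(F)F)c1` gives 4340 nM, and compound 3 `O=C(Nc1cccc(-n2cc(-c3ccncc3)c(-c3ccc(Cl)c(O)c3)n2)c1)Nc1ccc(Cl)c(C(F)(F)F)c1` gives 768 nM. Two single-point steps connect them: hydrogen in place of methyl on an oxygen on an aromatic ring gives a 4.7-fold higher number from compound 1 to compound 2 (0.67 log units; beyond the scatter), and chloro in place of hydrogen on an aromatic carbon gives a 5.7-fold lower number from compound 2 to compound 3 (0.75 log units; beyond the scatter). Compound 1 stands second highest of the three numbers, and compound 3 sits within the scatter of it, so the two cannot be ordered; only compound 2 separates from compound 1 beyond the scatter.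

Compound 4 `COc1cc(-c2nn(-c3cccc(NC(=O)Nc4ccc(Cl)c(Cl)c4)c3)cc2-c2ccncc2)ccc1Cl` has not yet been measured in this assay. It differs from compound 1 by 3,4-dichlorophenyl in place of 3-(trifluoromethyl)phenyl on an amide-type nitrogen. Among the measured compounds shown here, the only measured step on that part of the molecule is the one from compound 2 to compound 3, where chloro in place of hydrogen on an aromatic carbon lowered the number beyond the scatter; the step from compound 1 to compound 2 lies elsewhere and does not bear on this change. A single chloro addition is, however, not the same as the full exchange here, so a modest lowering at most is expected. Compound 4 is estimated at 650 nM, with a range of 250 nM to 1800 nM, meaning an expected step of a 1.4-fold lower number from compound 1 to compound 4 (0.15 log units; within the scatter).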

Compound 4, concentration for 50% growth inhibition: 1040 nM
Estimate against measurement, compound 4: 1.6-fold (0.20 log units) below, and the stated range covers the measured number.
By their numbers in this assay, from the lowest: compounds 3, 1 and 4 (each within the scatter of the next); then compound 2.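

In this assay, 3,4-dichlorophenyl in place of 3-(trifluoromethyl)phenyl on the amide-type nitrogen gives a step within the scatter (a 1.1-fold higher number from compound 1 to compound 4 (0.05 log units; within the scatter)), so on the core of compound 1 this exchange produces no change that can be read. The earlier step at this aryl group, chloro in place of hydrogen on an aromatic carbon (a 5.7-fold lower number from compound 2 to compound 3 (0.75 log units; beyond the scatter)), lay beyond the scatter, but it was seen with hydrogen in place of methyl on the oxygen and covered only a single chloro addition, whereas the new result covers a full exchange of the aryl group with the methyl retained. Nothing available explains why these two aryl groups read alike.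

Among the compounds shown here, still open is whether the same exchange also stays within the scatter on the core of compound 2, where the only measured change at this aryl group lay beyond it. On these data alone, the response of this position to an aryl group carrying a carboxylic acid or a dimethylamino group also remains open, as both lie outside the halogen and trifluoromethyl substituents seen so far.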